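The source may report more compounds than this note shows. Statements on the series, on what has been measured and on what is new or still open speak of the compounds shown alone.

Going by the values given here, in a functional assay on MKN-45 cells (Homo sapiens) for antiproliferative activity, with a stated time of 72 h (a lower number here means a stronger inhibitor, a higher number a weaker inhibitor), compound 1 `Cn1cc(-c2ccc(NC(=O)c3cn(CC4CCOCC4)cc(-c4ccc(F)cc4F)c3=O)cc2)c2c(N)ncnc21` gives 501 nM, the only actual number available for this small set. In this assay, compound 2 `CN(C)C(=O)Cn1cc(C(=O)Nc2ccc(-c3cn(C)c4ncnc(N)c34)cc2)c(=O)c(-c2ccc(F)cc2)c1` is reported only as a limit, > 100 nM. Compound 1 is therefore the sole numerical reference point. Compound 3 `Cn1cc(-c2ccc(NC(=O)c3cn(CC4CCOCC4)cc(-c4ccccc4)c3=O)cc2)c2c(N)ncnc21` keeps the core of compound 1 and its (oxan-4-yl)methyl group but differs in one substituent: phenyl in place of 2,4-difluorophenyl on an aromatic carbon. This places phenyl in place of 2,4-difluorophenyl on an aromatic carbon of a six-membered aromatic ring with 1 nitrogen. Among the compounds with values here, no measured step in this assay shows what this change does, so no step beyond the usual scatter is expected, with any drift more likely toward weaker inhibition. The estimated change is a 1.1-fold higher number from compound 1 to compound 3 (0.04 log units; within the scatter). For compound 3 the estimated value is 550 nM, with an expected range of 180 nM to 1700 nM.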

Compound 3, half-maximal inhibitory concentration: 318 nM
Estimate against measurement, compound 3: 1.7-fold (0.24 log units) above; low and high end bracket the measured number.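

In this assay, going by these compounds alone, phenyl in place of 2,4-difluorophenyl on this aromatic carbon gives a 1.6-fold lower number from compound 1 to compound 3 (0.20 log units; within the scatter), the first step that can be read at this position. Both fluorine atoms can thus leave this ring with no change beyond the scatter, so this step does not separate the two compounds, and this position tolerates either ring in the setting of the (oxan-4-yl)methyl group. Nothing shown here accounts for the size of this step.

Going by these compounds, whether a ring with a single fluorine, a methoxy group or an amine, or a pyridine ring in place of the phenyl, would move the number beyond the scatter stays open. On these data alone, whether the same swap behaves alike with a different group in place of the (oxan-4-yl)methyl group also stays open, and compound 2, whose reading is only a limit, cannot settle that.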